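Morpholin-4-yl for Thiomorpholin-4-yl on a Thiocarbonyl Carbon

The source may report more compounds than this note shows. Statements on the series, on what has been measured and on what is new or still open speak of the compounds shown alone.

In a functional assay on A-375 cells (Homo sapiens) for cytotoxicity, read by MTT assay, with a stated time of 72 h, tested at 100 uM (on this read-out lower numbers stand for less inhibition of growth and higher numbers for more inhibition of growth at the one concentration tested), the three measured compounds gave the following results:
compound 1, `Cc1ccnc(/C(N)=N/NC(=S)N2CCOCC2)c1`: 90.6%
compound 2, `Cc1cccc(/C(N)=N/NC(=S)N2CCSCC2)n1`: 77.4%
compound 3, `Cc1ccnc(/C(N)=N/NC(=S)N2CCSCC2)c1`: 89.9%

Compound 1 and compound 3 share a core and differ in one place: morpholin-4-yl in place of thiomorpholin-4-yl on a thiocarbonyl carbon. The step of a number 0.7 percentage points higher from compound 3 to compound 1 (within the scatter), so on this read-out the two groups give numbers that cannot be told apart.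

Compound 2 is built from the same atoms as compound 3, joined differently; the difference between the two cores is not broken down here. Compound 2 gives the lowest number of the three, and both compound 3 and compound 1 stand above it by more than the scatter.

Compound 4, `Cc1cccc(/C(N)=N/NC(=S)N2CCOCC2)n1`, has not yet been measured. Within the data shown here, it differs from compound 2 by morpholin-4-yl in place of thiomorpholin-4-yl on a thiocarbonyl carbon, which is the same change, at the same kind of place, as the one from compound 3 to compound 1. Since the step of a number 0.7 percentage points higher from compound 3 to compound 1 (within the scatter) was within the scatter, a step of similar size is expected here, and the estimate is a number 0.6 percentage points higher from compound 2 to compound 4 (within the scatter). This expectation rests on a single measured pair, so it carries the uncertainty of one example. Compound 4 is expected to give about 78%, with a likely range from 66% to 90%.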

Compound 4, percent growth inhibition at one concentration: 83.8%
The estimate for compound 4 lay 5.8 percentage points below the measured number, and the stated range covers the measured number.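

In this assay, morpholin-4-yl in place of thiomorpholin-4-yl on a thiocarbonyl carbon again gives two compounds that cannot be told apart, with a number 6.4 percentage points higher from compound 2 to compound 4 (within the scatter). Set beside the earlier pair, the change carries from one core to the other with no difference that stands out from the scatter: the same change on two cores in this assay, a number 0.7 percentage points higher (within the scatter) from compound 3 to compound 1 and a number 6.4 percentage points higher (within the scatter) from compound 2 to compound 4, 5.7 percentage points apart, within the scatter of two such steps. Among these compounds, this shows that, on these two cores and at the one concentration tested, the two groups can be exchanged without a step that can be read, but it does not show that the change has no effect at all, nor that the same would hold on any third core, since the finding rests on only two pairs in one cell line.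

The compounds shown leave open whether a ring or group of another kind on the same thiocarbonyl carbon, such as piperidin-1-yl, 4-methylpiperazin-1-yl or an open-chain dimethylamino group, would stay level with morpholin-4-yl and thiomorpholin-4-yl. They also leave open whether the two groups would still match if compared across a full series of concentrations rather than at a single one.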